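Does an ethoxy group lift compound 3 off its limit?

The source may report more compounds than this note shows. Statements on the series, on what has been measured and on what is new or still open speak of the compounds shown alone.

In a functional assay on HT-29 cells (Homo sapiens) for antiproliferative activity, read by MTT assay, with a stated time of 24 h (a higher number here means a weaker inhibitor, a lower number a stronger inhibitor), compound 1 `COc1ccc(C(=O)/C=C/c2ccc([N+](=O)[O-])cc2)c2c1C=CC(C)(C)O2` gives 3730 nM and compound 2 `COc1ccc(C(=O)/C=C/c2cccc([N+](=O)[O-])c2)c2c1C=CC(C)(C)O2` gives 4260 nM as its reading. The change between these two nitro compounds is a 1.1-fold higher number from compound 1 to compound 2 (0.06 log units; within the scatter) so the pair counts as equal. Compound 3 `COc1ccc(C(=O)/C=C/c2ccc(O)cc2)c2c1C=CC(C)(C)O2` reads > 10000 nM as a limit of the assay and not as a number. Putting a hydroxy group where the nitro group stood gave an at least 2.6-fold higher number from compound 1 to compound 3 (0.42 log units; beyond the scatter) and also an at least 2.3-fold higher number from compound 2 to compound 3 (0.37 log units; beyond the scatter) so compound 3 sits on the weak side of both nitro compounds.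

Compound 4 `CCOc1cc(/C=C/C(=O)c2ccc(OC)c3c2OC(C)(C)C=C3)ccc1O` is compound 3 with a single addition: ethoxy in place of hydrogen on an aromatic carbon that is, ethoxy in place of hydrogen on an aromatic carbon, ortho to a hydroxy group. Among the measured compounds shown here, no measured step adds an ethoxy group, so none gives its size directly. Compound 4 keeps the hydroxy group that came with an at least 2.3-fold higher number from compound 2 to compound 3 (0.37 log units; beyond the scatter) so a reading close to that of compound 3 is expected. In this assay no step beyond the scatter is expected, and another limit would be no surprise. The expected step is a step that the limit leaves unreadable from compound 3 to compound 4 as an estimate only. For compound 4 the estimated value is 12000 nM with an expected range from 5000 nM to 30000 nM overall.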

Compound 4, half-maximal inhibitory concentration: > 10000 nM
Compound 4: no number, only a limit (the forecaster's own chance of this, stated with the estimate: 55%); the middle value is on the limit's open side.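

Compound 4, like compound 3, gives only a limit in this assay and not a number, so no step can be read between the two: the limit of > 10000 nM in this assay, at which 2 of the 4 values shown sit.

On these data alone, whether ethoxy in place of hydrogen changes the activity of compound 3 at all stays open, and so does how far beyond the limit either compound lies.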